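From 4-bromophenyl to 3-chloro-4-fluorophenyl on the amide

The source may hold more compounds than are shown below. What is called first, only, known or untested is meant among the compounds shown, and "the series" means these compounds.

Measured in an ADME assay on HUVEC cells (Homo sapiens) for cytotoxicity, read by MTT assay, with a stated time of 72 h (a higher number here means a weaker inhibitor, a lower number a stronger inhibitor), so far
- compound 1 `O=C(O)CCC(=O)OCCCCCCSc1ccc([N+](=O)[O-])c2nonc12` gives 740 nM
- compound 2 `O=C(CCC(=O)OCCCCCCSc1ccc([N+](=O)[O-])c2nonc12)Nc1ccccc1` gives 2490 nM
- compound 3 `O=C(CCC(=O)OCCCCCCSc1ccc([N+](=O)[O-])c2nonc12)Nc1ccc(Br)cc1` gives 1610 nM

Compound 3 is placed by two steps. One is a 2.2-fold higher number from compound 1 to compound 3 (0.34 log units; beyond the scatter), which sets it clearly apart. The other is a 1.5-fold lower number from compound 2 to compound 3 (0.19 log units; within the scatter), which does not separate the pair.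

Compound 4 `O=C(CCC(=O)OCCCCCCSc1ccc([N+](=O)[O-])c2nonc12)Nc1ccc(F)c(Cl)c1` has not yet been measured. It carries 3-chloro-4-fluorophenyl in place of 4-bromophenyl on an amide-type nitrogen, with 3-chloro-4-fluorophenyl in place of 4-bromophenyl on an amide-type nitrogen.

Within the data shown here, the only measured change on this aromatic ring, bromo in place of hydrogen, is a 1.5-fold lower number from compound 2 to compound 3 (0.19 log units; within the scatter). The larger steps, a 3.4-fold higher number from compound 1 to compound 2 (0.53 log units; beyond the scatter) and a 2.2-fold higher number from compound 1 to compound 3 (0.34 log units; beyond the scatter), replace hydroxy on a carbonyl carbon, a change that compound 4 does not make. No step beyond the scatter is therefore expected, and the expected step is a 1.1-fold higher number from compound 3 to compound 4 (0.02 log units; within the scatter). The estimate for compound 4 is 1700 nM, with an expected range from 900 nM to 3200 nM.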

Compound 4, half-maximal inhibitory concentration: 2320 nM
Beside the measured number, compound 4's estimate is 1.4-fold (0.14 log units) below it, and the stated range covers the measured number.
By their numbers in this assay, from the lowest: compound 1; then compounds 3, 4 and 2 (each within the scatter of the next).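

In this assay, 3-chloro-4-fluorophenyl in place of 4-bromophenyl on the amide-type nitrogen gives a 1.4-fold higher number from compound 3 to compound 4 (0.16 log units; within the scatter) and 3-chloro-4-fluorophenyl in place of phenyl gives a 1.1-fold lower number from compound 2 to compound 4 (0.03 log units; within the scatter), so neither change separates compound 4 from its neighbours, and this position now holds two halogens on the ring without a step beyond the scatter. The change at the carbonyl carbon still stands apart, with (3-chloro-4-fluorophenyl)amino in place of hydroxy giving a 3.1-fold higher number from compound 1 to compound 4 (0.50 log units; beyond the scatter), the same direction seen for compounds 2 and 3. Nothing shown gives a reason for these numbers.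

As far as these compounds go, it remains open whether an amine or a carboxylic acid on this aromatic ring would move the number beyond the scatter. Among these compounds, it is also open how a longer chain in place of the one shared here would change it.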